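Chain Lengthening on Two Acetophenone-Type Cores

The compounds below may be only part of what the source reports. "The series", "measured", "known", "first", "only" and "open" are said of these compounds alone.

Measured compounds:
compound 1, `CCCCCCCCOc1cc(OC)c(Br)cc1C(C)=O`, 32000000 nM in a functional assay, read by spectrophotometry, with a stated time of 6 min; on this read-out higher numbers stand for weaker inhibition and lower numbers for stronger inhibition
compound 2, `CCCCCCCCCCOc1cc(OC)c(Br)cc1C(C)=O`, 34700000 nM in this assay
compound 3, `CCCCCCCCCCCCCCOc1cc(OC)ccc1C(C)=O`, 38000000 nM in this assay

Compound 1 and compound 2 share one core and differ only by ethyl in place of hydrogen on a saturated chain carbon, eight bonds along the chain from an oxygen on an aromatic ring. In this assay this gave a 1.1-fold higher number from compound 1 to compound 2 (0.04 log units; within the scatter), so lengthening the chain here did not shift the read-out beyond ordinary noise. Compound 3 carries a different core; how that core differs from the core of compound 1 is not broken down here, and the numbers for compound 3 and compound 2 sit within the usual scatter of one another.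

Compound 4, `CCCCCCCCCCCCCCCCOc1cc(OC)ccc1C(C)=O`, is not yet measured. It differs from compound 3 by ethyl in place of hydrogen on a saturated chain carbon, ten or more bonds along the chain from an oxygen on an aromatic ring. This is the same kind of change as that from compound 1 to compound 2, though not at the same place: the entering ethyl is set at a different point along the chain from the ring oxygen. Compound 4 is expected to give a 1.1-fold higher number from compound 3 to compound 4 (0.02 log units; within the scatter) in this assay, resting on compound 1 to compound 2, where the step was a 1.1-fold higher number from compound 1 to compound 2 (0.04 log units; within the scatter). The estimate for compound 4 in this assay is 40000000 nM, between 24000000 nM and 68000000 nM.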

Compound 4, half-maximal inhibitory concentration: 36300000 nM
The estimate for compound 4 lay 1.1-fold (0.04 log units) above the measured number; measured number inside the range.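

In this assay, the new step is a 1.0-fold lower number from compound 3 to compound 4 (0.02 log units; within the scatter), so putting ethyl in place of hydrogen on the chain left the read-out within ordinary noise on this core as well. Set beside the earlier step, the same change gave results on the two cores that cannot be told apart: the same change on two cores in this assay, a 1.1-fold higher number (0.04 log units; within the scatter) from compound 1 to compound 2 and a 1.0-fold lower number (0.02 log units; within the scatter) from compound 3 to compound 4, 1.1-fold (0.06 log units) apart, within the scatter of two such steps. This shows that the lack of a readable effect carried over from one core to the other, but it does not show that a real effect of a chain change would carry over, as two steps this small give no size to compare.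

As far as these compounds go, it remains open whether a chain ending in an amine or a carboxylic acid, or a much shorter chain such as methyl, would move the read-out beyond the scatter on either core. From the compounds shown here alone, the effect of the difference between the two cores on its own also remains open.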